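The source may report more compounds than this note shows. Statements on the series, on what has been measured and on what is new or still open speak of the compounds shown alone.

Measured in a functional assay on CCRF-CEM cells (Homo sapiens) for inhibition; on this read-out higher numbers stand for weaker inhibition and lower numbers for stronger inhibition:
- compound 1 `CN(C)c1ccc(/C=C2\CCc3ccccc3C2=O)cc1`: 1650 nM
- compound 2 `O=C1CCCCC/C1=C\c1ccc(Cl)cc1`: 43500 nM

Of these two, compound 2 has the higher number, at 43500 nM, and the gap to compound 1 lies beyond the scatter. Compound 3 `Cc1ccc(/C=C2\CCCCCC2=O)cc1` differs from compound 2 by methyl in place of chloro on an aromatic carbon, with methyl in place of chloro on an aromatic carbon. For the measured compounds named here, no measured pair shows this change, and no step beyond the scatter is expected in this assay. The estimated step of a 1.1-fold lower number from compound 2 to compound 3 (0.04 log units; within the scatter) is small and carries no firm direction. For compound 3 the expected value is 40000 nM, with an estimated range of 15000 nM to 100000 nM.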

Compound 3, half-maximal inhibitory concentration: > 500000 nM
Compound 3 ended at the assay's limit; the forecaster's own chance of this, stated with the estimate: 15%; middle value at least 12-fold (1.09 log units) away from the limit.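

Swapping chloro for methyl at the aromatic carbon para to the group of 9 heavy atoms is no silent exchange: this assay records an at least 11-fold higher number from compound 2 to compound 3 (1.06 log units; beyond the scatter). This one position on the shared core therefore decides whether a value can be read at all. Compound 3 stands at a limit, not at a number, so the step has only a lower bound: the limit of > 500000 nM in this assay, at which 1 of the 3 values shown sits.

From the compounds shown here alone, whether fluoro, methoxy or a nitrile at this position would stay nearer compound 2 remains open. So does whether the same change would give a similar step on the core of compound 1.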